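This account rests on a few compounds, and the source may have more. Where it says the series, first, only, none or still open, it means among the compounds named here.

- compound 1 `Cc1c(OCCCCOc2ccc(C(=O)O)cc2)ccc(C(=O)CC(C)C)c1O`: 66%
- compound 2 `Cc1c(OCCCCOc2ccc(C(=O)O)cc2Cl)ccc(C(=O)CC(C)C)c1O`: 61%

In an ADME assay (liver) for metabolic stability, with Liver microsome (Rattus norvegicus) as the target, read by LC-MS, using microsomes and NADPH, with stated times of 5 min and 60 min, tested at 4 uM (on this read-out higher numbers stand for a more stable compound and lower numbers for a less stable compound), compound 2 gives 61%, which lies within the scatter of compound 1. Compound 3 `Cc1ccc(C(=O)O)cc1OCCCCOc1ccc(C(=O)CC(C)C)c(O)c1C` differs from compound 2 as follows: 5-carboxy-2-methylphenyl in place of 4-carboxy-2-chlorophenyl on an oxygen on a saturated carbon. For the measured compounds named here, the only measured step on that part of the structure is a number 5 percentage points lower from compound 1 to compound 2 (within the scatter). Going by the values given here, no measurement yet covers a 5-carboxy-2-methylphenyl group. Among the compounds with values here, with only that small step to go on, no change beyond the scatter is expected in this assay. The expected step is a number 6 percentage points lower from compound 2 to compound 3 (within the scatter). For compound 3 the estimated value is 55%, with an expected range of 38% to 72%.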

Compound 3, percent of the compound remaining: 21%
For compound 3 the middle estimate is 34 percentage points above the measured one; the measured number lies below the stated range.
By their numbers in this assay, from the lowest: compound 3; then compounds 2 and 1 (each within the scatter of the next).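

In this assay the aryl group on an oxygen on a saturated carbon proves far from indifferent, as the earlier chloro step within the scatter could not show: 5-carboxy-2-methylphenyl in place of 4-carboxy-2-chlorophenyl gives a large fall (a number 40 percentage points lower from compound 2 to compound 3 (beyond the scatter)). The same group in place of 4-carboxyphenyl gives a similar one (a number 45 percentage points lower from compound 1 to compound 3 (beyond the scatter)). Nothing measured here accounts for this fall. The compounds shown leave open whether the methyl group or the changed place of the carboxy group carries the step, and how a tetrazole or primary amide in place of the carboxy group would read.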